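A Bromo-Methyl Aryl Swap in a Weakly Active Set

The compounds below may be only part of what the source reports. "The series", "measured", "known", "first", "only" and "open" are said of these compounds alone.

Of the compounds shown here, three sharing one core have been tested in a functional assay on IMR-32 cells (Homo sapiens) for antiproliferative activity, read by MTT assay; a lower number here means a stronger inhibitor, a higher number a weaker inhibitor. Among them, compound 1 `CC1(C)CCc2cc(C(=O)/C=C/c3ccc(OCc4cn(-c5ccc(Cl)cc5)nn4)cc3)c(O)cc2O1` gives 92100 nM, the only actual number in the set. Compound 2 `COc1ccc(-n2cc(COc3ccc(/C=C/C(=O)c4cc5c(cc4O)OC(C)(C)CC5)cc3)nn2)c([N+](=O)[O-])c1` is recorded as "not active" (no number reported). Compound 3 `CC(=O)c1ccc(-n2cc(COc3ccc(/C=C/C(=O)c4cc5c(cc4O)OC(C)(C)CC5)cc3)nn2)cc1` has no single number either and is recorded as "not active" (no number reported). Compound 4 `Cc1ccc(-n2cc(COc3ccc(/C=C/C(=O)c4cc5c(cc4O)OC(C)(C)CC5)cc3)nn2)cc1Br` has not yet been measured. The structural change 3-bromo-4-methylphenyl in place of 4-acetylphenyl on an aromatic nitrogen puts 3-bromo-4-methylphenyl in place of 4-acetylphenyl on an aromatic nitrogen. For the measured compounds named here, no measured step guides this swap, so at most a modest shift from no reported activity to weak, measurable activity is expected, near compound 1 at 92100 nM. Compound 4 is estimated at 70000 nM, with an expected range of 25000 nM to 200000 nM.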

Compound 4, half-maximal inhibitory concentration: "not active" (no number reported)
The entry for compound 4 holds no number; the estimate stays without a comparison.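

Compound 3 and compound 4 are both recorded as not active, without a number, so no step can be read between them. The compounds shown leave open what separates compound 1, at 92100 nM, from these entries. No evidence at hand bears on this result.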